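Adding a Third Methoxy Group to a Lactam Analogue

A few compounds are considered here, and "the series" means these few. Any claim that something is new, unique, unknown or untested is made for them only; others in the source may bear on it.

Compound 2 `COc1cc(/C=C/C2CC=CC(=O)N2)cc(OC)c1` and compound 1 `COc1cc(/C=C/C2CC(=O)C=CO2)cc(OC)c1OC` were both tested in an ADME assay on HaCaT cells (Homo sapiens) for inhibition, read by sulforhodamine B assay, with a stated time of 48 h; on this read-out higher numbers stand for weaker inhibition of growth and lower numbers for stronger inhibition of growth. In this assay compound 2 gives 212 uM, and compound 1 gives 155 uM, so the two numbers lie within the usual scatter of each other. Compound 3 `COc1cc(/C=C/C2CC=CC(=O)N2)cc(OC)c1OC` differs from compound 2 by one change: methoxy in place of hydrogen on an aromatic carbon. Among the measured compounds shown here, no measured pair shows this same change, so only a modest effect is expected. The step from compound 2 to compound 3 is expected to be a 1.2-fold lower number from compound 2 to compound 3 (0.07 log units; within the scatter), not beyond the scatter. Compound 3 is therefore estimated at 180 uM, in the range 90 uM to 360 uM.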

Compound 3, concentration for growth inhibition (reported as GI): > 864 uM
Compound 3: a limit, no number; the forecaster's own chance of this, stated with the estimate: 5%; middle value at least 4.8-fold (0.68 log units) from the limit.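

Compound 3 gives a limit of the assay, not a number: the limit of > 864 uM in this assay, at which 1 of the 3 values shown sits.

Even so, this position is not indifferent to the change: methoxy in place of hydrogen, ortho to two methoxy groups, brings an at least 4.0-fold higher number from compound 2 to compound 3 (0.61 log units; beyond the scatter), which means weaker inhibition of growth. The non-aromatic ring group matters as well: with the same three methoxy groups, exchanging that group brings an at least 5.5-fold higher number from compound 1 to compound 3 (0.74 log units; beyond the scatter).

On these data alone, the true value of compound 3 remains open, since only its limit is known. Also open, as far as these compounds go, is whether a smaller group at this position, such as a hydroxy group or an amine, would weaken inhibition in this assay in the same way.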